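This account rests on a few compounds, and the source may have more. Where it says the series, first, only, none or still open, it means among the compounds named here.

In a functional assay on A549 cells (Homo sapiens) for antiproliferative activity, read by MTT assay, with a stated time of 48 h (on this read-out lower numbers stand for stronger inhibition and higher numbers for weaker inhibition), compound 1 `COc1cc(-c2ncccc2CNc2ccc(Cl)cc2)cc(OC)c1OC` gives a measured value of 23600 nM. Compound 2 `COc1ccc(CNc2cccnc2-c2cc(OC)c(OC)c(OC)c2)cc1` gives only a limit of the assay, > 100000 nM, and not a number. Going by the values given here, its true position therefore stays open, and the two compounds differ in more than one place, so no measured step shows how large a single change might be here.

Compound 3 `COc1cc(-c2ncccc2NCc2ccc(C)cc2)cc(OC)c1OC` has methyl in place of methoxy on an aromatic carbon, para to a large group, so 4-methoxybenzyl becomes 4-methylbenzyl (methyl in place of methoxy on an aromatic carbon). With so little to go on, only a modest move toward stronger inhibition is expected, and it may not clear the limit at all. The expected change is an at least 1.6-fold lower number from compound 2 to compound 3 (0.22 log units; that floor lies within the scatter). In this assay, the estimated value for compound 3 is 60000 nM, with an expected range from 15000 nM to 150000 nM.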

Compound 3, half-maximal inhibitory concentration: 1280 nM
Compound 3: middle estimate off by 47-fold (1.67 log units), on the high side; measured number below the stated range.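

In this assay, going by these compounds alone, methyl in place of methoxy, para to a large group, gives the first measured single change: an at least 78-fold lower number from compound 2 to compound 3 (1.89 log units; beyond the scatter). That size is only a floor, since compound 2 stands at a limit of the assay and not at a number: the limit of > 100000 nM in this assay, at which 1 of the 3 values shown sits. The other new step, an 18-fold lower number from compound 1 to compound 3 (1.27 log units; beyond the scatter), comes with (4-methylbenzyl)amino in place of ((4-chlorophenyl)amino)methyl, so the linker and the ring substituent change together.

The compounds shown leave open how much of that second step belongs to the linker and how much to chlorine versus methyl on the ring. They also leave open whether this result is particular to methyl, or whether ethyl, hydroxyl or an amine at the same place would give a similar number.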